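Adding a methyl to compound 1

This account rests on a few compounds, and the source may have more. Where it says the series, first, only, none or still open, it means among the compounds named here.

Compound 1 `COc1cc(/C=C/Cc2cc(O)c3ccoc3c2)cc(OC)c1OC` gives 27700 nM
Compound 2 `COc1cc(/C=C\Cc2cc(O)c3cc(C)sc3c2)cc(OC)c1OC` gives 23 nM
Compound 3 `COc1cc(/C=C/Cc2cc(O)c3cc(C)sc3c2)cc(OC)c1OC` gives 840 nM
Compound 4 `COc1cc(/C=C/Cc2cc(O)c3cc(C)oc3c2)cc(OC)c1OC` is not yet measured

In a functional assay on BMEC cells (Bos taurus) for antiproliferative activity (on this read-out higher numbers stand for weaker inhibition and lower numbers for stronger inhibition), compound 1 has the highest number of the three, so it is the weakest inhibitor so far. The change to compound 4 is methyl in place of hydrogen on an aromatic carbon.

Among the compounds with values here, the only measured step is a 37-fold higher number from compound 2 to compound 3 (1.56 log units; beyond the scatter), which is large and goes with the fact that compounds 2 and 3 differ only in the configuration as drawn. It bears only indirectly, since the double bond is drawn E in both compound 1 and compound 4. Within the data shown here, no measured step isolates the methyl. Compound 3 also has an E double bond and a methyl, and it gives 840 nM, but its core differs from that of compound 1 by more than the methyl. A clear move to a lower number in this assay, covering part of that gap, is therefore expected, with wide uncertainty. The expected change is a 5.5-fold lower number from compound 1 to compound 4 (0.74 log units; beyond the scatter). For compound 4 the estimated value is 5000 nM, with an expected range of 1000 nM to 25000 nM.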

Compound 4, half-maximal inhibitory concentration: 12300 nM
Estimate against measurement, compound 4: 2.5-fold (0.39 log units) below; low and high end bracket the measured number.
By their numbers in this assay, from the lowest: compound 2; then compound 3; then compound 4; then compound 1.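

Methyl in place of hydrogen on an aromatic carbon of the five-membered aromatic ring, next to the ring oxygen, gives a 2.3-fold lower number from compound 1 to compound 4 (0.35 log units; beyond the scatter) in this assay. Within the data shown here, this is the first measured step that isolates a change at this position with the double bond drawn E on both sides, and it shows that the position accepts a methyl with a modest move towards stronger inhibition. The methyl alone does not close the gap to the printed number of compound 3, which gives 840 nM, against 12300 nM for compound 4. Nothing in the available evidence accounts for the size of this methyl step.

Open, from the compounds shown here alone, is whether an ethyl group, a longer chain, an amine or a carboxylic acid at this position would move the number further, or in the opposite direction. Also open, going by these compounds, is how large the methyl step would be with the double bond drawn Z on the same core.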